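The source may report more compounds than this note shows. Statements on the series, on what has been measured and on what is new or still open speak of the compounds shown alone.

Compound 1, with the structure `CCCCCCOc1cc(NC(=O)c2ccc(I)cc2)ccc1N(C)S(C)(=O)=O`, is the point from which the other three are read. In a functional assay on SK-BR-3 cells (Homo sapiens) for antiproliferative activity, read by MTT assay, with a stated time of 48 h (a higher number here means a weaker inhibitor, a lower number a stronger inhibitor), compound 1 gives 12700 nM. Compound 2, with the structure `CCCCCCOc1cc(NC(=O)c2ccc3ccccc3c2)ccc1N(C)S(C)(=O)=O`, differs from it by one change, (naphthalen-2-yl in place of 4-iodophenyl on a carbonyl carbon). In this assay compound 2 gives 64300 nM, and the step of a 5.1-fold higher number from compound 1 to compound 2 (0.70 log units; beyond the scatter) goes in the direction of a weaker inhibitor.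

Compound 3, with the structure `Cc1ccc(C(F)(F)F)cc1COc1cc(NC(=O)c2ccc(I)cc2)ccc1N(C)S(C)(=O)=O`, carries a different core. How the two cores differ is told by 2-methyl-5-(trifluoromethyl)phenyl in place of pentyl on a saturated chain carbon bound to an oxygen on an aromatic ring. In this assay compound 3 gives 3500 nM, and the step of a 3.6-fold lower number from compound 1 to compound 3 (0.56 log units; beyond the scatter) makes it the strongest inhibitor among the three measured compounds, its steps to compound 1 and to compound 2 both lying beyond the scatter.

Compound 4, with the structure `Cc1ccc(C(F)(F)F)cc1COc1cc(NC(=O)c2ccc3ccccc3c2)ccc1N(C)S(C)(=O)=O`, has not yet been measured in this assay. It differs from compound 3 by naphthalen-2-yl in place of 4-iodophenyl on a carbonyl carbon. Within the data shown here, this is the same change as the one from compound 1 to compound 2, and it sits at the same place, a carbonyl carbon whose other neighbour is an amide-type nitrogen. The change occurs twice among the four compounds, once measured and once not. Since the step of a 5.1-fold higher number from compound 1 to compound 2 (0.70 log units; beyond the scatter) was a modest weakening, a step of similar size is expected on the core of compound 3, giving an expected 4.9-fold higher number from compound 3 to compound 4 (0.69 log units; beyond the scatter). On that basis compound 4 is estimated to give about 17000 nM in this assay, with a likely range from 7000 nM to 45000 nM.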

Compound 4, half-maximal inhibitory concentration: 18400 nM
Compound 4: middle estimate off by 1.1-fold (0.03 log units), on the low side; low and high end bracket the measured number.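

In this assay, naphthalen-2-yl in place of 4-iodophenyl on a carbonyl carbon gives a 5.3-fold higher number from compound 3 to compound 4 (0.72 log units; beyond the scatter), and this step carries over from the core of compound 1 to the core of compound 3 with no difference beyond the scatter: the same change on two cores in this assay, a 5.1-fold higher number (0.70 log units; beyond the scatter) from compound 1 to compound 2 and a 5.3-fold higher number (0.72 log units; beyond the scatter) from compound 3 to compound 4, 1.0-fold (0.02 log units) apart, within the scatter of two such steps. The other change, 2-methyl-5-(trifluoromethyl)phenyl in place of pentyl, gives a 3.5-fold lower number from compound 2 to compound 4 (0.54 log units; beyond the scatter), and it too is the same whether the carbonyl carbon bears 4-iodophenyl or naphthalen-2-yl: the same change on two cores in this assay, a 3.6-fold lower number (0.56 log units; beyond the scatter) from compound 1 to compound 3 and a 3.5-fold lower number (0.54 log units; beyond the scatter) from compound 2 to compound 4, 1.0-fold (0.02 log units) apart, within the scatter of two such steps. Within these four compounds the two changes therefore combine without any detectable interaction, but each comparison rests on a single pair of steps in one cell assay, so this does not show that either step would hold on another core, and it says nothing about why either change has the effect it does.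

Going by these compounds, it remains open whether steps of this size would persist with a longer chain in place of pentyl, or with a phenyl group bearing an amine or a carboxylic acid in place of 4-iodophenyl. On these data alone, the sulfonamide part is the same in all four compounds, so the effect of replacing it, for example with a plain amide, also remains open.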